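Swapping Chloro for Methyl: Expecting Only a Small Step

This account rests on a few compounds, and the source may have more. Where it says the series, first, only, none or still open, it means among the compounds named here.

The three measured compounds and their numbers:
compound 1 `COC(=O)c1cc(-c2csc(N/N=C/c3cccs3)n2)ccc1OCc1ccccc1` gives 79.6%
compound 2 `Clc1ccc(-c2csc(N/N=C/c3cccs3)n2)cc1` gives 82.8%
compound 3 `COC(=O)c1cc(-c2csc(N/N=C/c3ccc(Cl)cc3Cl)n2)ccc1OCc1ccccc1` gives 58.9%

In a functional assay, read by spectrophotometry, with a stated time of 15 min, tested at 20 ug/mL (on this read-out lower numbers stand for a weaker effect and higher numbers for a stronger effect at the one concentration tested), compound 2 stands highest of the three numbers, yet its nearest neighbour, compound 1, sits within the scatter of it, so the two cannot be ordered. Only compound 3 lies clearly apart, beyond the scatter. For the measured compounds named here, the single step measured between compounds that differ in one place is a number 20.7 percentage points lower from compound 1 to compound 3 (beyond the scatter), where 2,4-dichlorophenyl enters in place of thiophen-2-yl on a carbon with a double bond to nitrogen.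

Compound 4 `Cc1ccc(-c2csc(N/N=C/c3cccs3)n2)cc1` differs from compound 2 in a different part of the molecule: methyl in place of chloro on an aromatic carbon on a six-membered aromatic ring of carbon only, para to a large group. Going by the values given here, no measured step touches that position or exchanges chloro for methyl, so the one step that exists, concerning the other end of the shared core, does not bear on it. With nothing to point in either direction, the author expects the step of a number 6.8 percentage points lower from compound 2 to compound 4 (within the scatter) to stay within the scatter. Compound 4 is therefore estimated at 76%, with a range from 60% to 88%.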

Compound 4, a percentage reported as inhibition, at one concentration (the size of the read-out at that concentration, not a potency): 79.6%
Estimate against measurement, compound 4: 3.6 percentage points below; the measured number falls inside the stated range.
By their numbers in this assay, from the lowest: compound 3; then compounds 1, 4 and 2 (each within the scatter of the next).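

In this assay, methyl in place of chloro on an aromatic carbon of a six-membered aromatic ring of carbon only, para to a large group, gives a number 3.2 percentage points lower from compound 2 to compound 4 (within the scatter), so the read-out does not separate these two compounds and this one exchange at this position leaves no measurable mark at the one concentration tested. For the compounds shown here, the earlier compounds could not show this: their only step, a number 20.7 percentage points lower from compound 1 to compound 3 (beyond the scatter), concerns the other end of the shared core, and it lies beyond the scatter, whereas the first step measured at this position lies within it. No measurement shown here offers a reason why chloro and methyl read alike in this setting.

Going by these compounds alone, because chloro and methyl are the only two groups compared at this position, it remains open whether an amine, a carboxylic acid or a longer chain such as butyl on the same aromatic carbon would also stay within the scatter of compound 2. On these data alone, it also remains open whether the exchange of chloro for methyl would read the same with 2,4-dichlorophenyl in place of thiophen-2-yl, and, with a single concentration, whether compound 2 and compound 4 would match in potency.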